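The compounds below may be only part of what the source reports. "The series", "measured", "known", "first", "only" and "open" are said of these compounds alone.

Of the compounds shown here, three sharing a core have been measured so far in an ADME assay on Vero cells (Chlorocebus sabaeus) for inhibition; a lower number here means that less compound is tolerated, a higher number that more compound is tolerated. Compound 1 (`O=C1/C(=C/c2ccc(Cl)cc2)CCC/C1=C\c1ccc(Cl)cc1`) gives 32100 nM, compound 2 (`COc1ccc(/C=C2\CCC/C(=C\c3ccc(N(C)C)cc3)C2=O)cc1`) gives 392000 nM, and compound 3 (`COc1ccc(/C=C2\CCC/C(=C\c3ccccc3Cl)C2=O)cc1`) gives 238000 nM. Compound 3 therefore stands within the scatter of compound 2, so those two values cannot be told apart. Its gap to compound 1 lies beyond the scatter, with compound 3 showing the higher number.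

Compound 4 (`COc1ccc(/C=C2\CCC/C(=C\c3ccc(Cl)cc3)C2=O)cc1`) has not yet been measured. It departs from compound 3 by a single change, 4-chlorophenyl in place of 2-chlorophenyl on a double-bonded chain carbon bound to a double-bonded ring carbon.

Among the measured compounds shown here, no measured pair shows this change on its own, so direct evidence for its size is lacking. For the measured compounds named here, the only guide is compound 1, which also carries 4-chlorophenyl and gives 32100 nM, although it differs from compound 3 elsewhere too. A moderate move toward a lower number in this assay is therefore expected, and it may not clear the scatter. The estimated step is a 2.0-fold lower number from compound 3 to compound 4 (0.30 log units; within the scatter). For compound 4 the expected value is 120000 nM, with an estimated range from 45000 nM to 300000 nM.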

Compound 4, half-maximal cytotoxic concentration: 401000 nM
The estimate for compound 4 lay 3.3-fold (0.52 log units) below the measured number, outside the stated range (above it).
By their numbers in this assay, from the lowest: compound 1; then compounds 3, 2 and 4 (each within the scatter of the next).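

Putting 4-chlorophenyl in place of 2-chlorophenyl on a double-bonded chain carbon bound to a double-bonded ring carbon gives, in this assay, a 1.7-fold higher number from compound 3 to compound 4 (0.23 log units; within the scatter) and so leaves no readable difference at this position. Chloro in place of dimethylamino on an aromatic carbon likewise gives a 1.0-fold higher number from compound 2 to compound 4 (0.01 log units; within the scatter) in this assay, whereas methoxy in place of chloro on an aromatic carbon gives a 12-fold higher number from compound 1 to compound 4 (1.10 log units; beyond the scatter) and is the only single change here that clears the scatter, so the 4-chlorophenyl group shared by compound 1 and compound 4 does not by itself go with the low number of compound 1. Nothing available here accounts for why that one exchange stands apart from the other two.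

Still open, on these data alone, is whether a group of another kind on the double-bonded chain carbon, such as a carboxylic acid or a morpholine in place of the chlorophenyl, would move the number at a position that has so far tolerated the chlorine's relocation. Also open, as far as these compounds go, is whether the exchange on the aromatic carbon is specific to methoxy, or whether fluoro or ethoxy in place of chloro would give a step of similar size.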